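One More Side Chain Change at an Assay Limit

This account rests on a few compounds, and the source may have more. Where it says the series, first, only, none or still open, it means among the compounds named here.

In a functional assay on MDA-MB-231 cells (Homo sapiens) for antiproliferative activity, read by CCK-8 assay, with a stated time of 48 h (on this read-out lower numbers stand for stronger inhibition and higher numbers for weaker inhibition), three compounds sharing one core have been tested so far. Compound 1 (`C=CC(=O)NCCOc1ccc(Oc2c(-c3ccc(F)cc3)sc3cc(O)ccc23)cc1`) gives a limit and no number (> 50000 nM). Compound 2 (`C/C=C/C(=O)NCCOc1ccc(Oc2c(-c3ccc(F)cc3)sc3cc(O)ccc23)cc1`) also gives a limit (> 50000 nM). Compound 3 (`CN(C)C(=O)/C=C/CN1CC(Oc2ccc(Oc3c(-c4ccc(F)cc4)sc4cc(O)ccc34)cc2)C1`), the starting point here, gives a limit as well (> 50000 nM). It therefore cannot be ranked against the other two, and the whole set looks the same (the limit of > 50000 nM in this assay, at which 3 of the 3 values shown sit).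

Compound 4 (`C=C(C)C(=O)N1CC(Oc2ccc(Oc3c(-c4ccc(F)cc4)sc4cc(O)ccc34)cc2)C1`) keeps the shared core and changes one group on an amine nitrogen in a ring: (1-methylethenyl)carbonyl in place of 3-(dimethylcarbamoyl)prop-2-en-1-yl ((1-methylethenyl)carbonyl in place of 3-(dimethylcarbamoyl)prop-2-en-1-yl on an amine nitrogen in a ring).

Among the compounds with values here, three measured steps bear on this change, and none has a size that can be read: (a step that the two limits leave unreadable from compound 1 to compound 2), (a step that the two limits leave unreadable from compound 1 to compound 3) and (a step that the two limits leave unreadable from compound 2 to compound 3). Each of these changes left the result at the same limit, so the data offer no sign of a group that moves the read-out. The step expected in this assay is a number no higher from compound 3 to compound 4 (the limit leaves the size open) and no direction can be foreseen for it. Compound 4 is estimated at 50000 nM and is expected to fall in a range from 20000 nM to 100000 nM and quite possibly to return only a limit.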

Compound 4, half-maximal inhibitory concentration: > 50000 nM
Compound 4: a limit, no number (the forecaster's own chance of this, stated with the estimate: 80%); the middle value lies on the limit itself.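

In this assay compound 4 gives > 50000 nM, which is a limit and not a number. Its steps from compound 1, compound 2 and compound 3 therefore cannot be read, and the whole set stays at one limit: the limit of > 50000 nM in this assay, at which 4 of the 4 values shown sit. The compounds shown leave open whether any side chain on the shared core can give a measurable value.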